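Carbonyl-substituent variation on the shared core

The source may hold more compounds than are shown below. What is called first, only, known or untested is meant among the compounds shown, and "the series" means these compounds.

Values in an assay on HL-60 cells for agonist activity at vitamin D3 receptor (Homo sapiens), read by microscopy, with a stated time of 96 h; on this read-out higher numbers stand for an effect only at larger amounts of compound and lower numbers for an effect already at smaller amounts:
compound 1 `CCOC(=O)CN(C)C(=O)c1ccc(C(CC)(CC)c2ccc(OCC(=O)C(C)(C)C)c(C)c2)n1CC`: > 50000 nM, a limit of the assay
compound 2 `C=CCN(C)C(=O)c1ccc(C(CC)(CC)c2ccc(OCC(=O)C(C)(C)C)c(C)c2)n1CC`: 21600 nM
compound 3 `C#CCCOC(=O)c1ccc(C(CC)(CC)c2ccc(OCC(=O)C(C)(C)C)c(C)c2)n1CC`: 28800 nM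

Compound 3 holds the highest of the two numbers, but the gap a 1.3-fold higher number from compound 2 to compound 3 (0.12 log units; within the scatter) is within the scatter, so no order between compound 2 and compound 3 is claimed. Against compound 1 only a limit is known (the limit of > 50000 nM in this assay, at which 1 of the 3 values shown sits), giving an at least 2.3-fold lower number from compound 1 to compound 2 (0.36 log units; beyond the scatter) and an at least 1.7-fold lower number from compound 1 to compound 3 (0.23 log units; that floor lies within the scatter).

Compound 4 `CCOC(=O)c1ccc(OC(=O)c2ccc(C(CC)(CC)c3ccc(OCC(=O)C(C)(C)C)c(C)c3)n2CC)cc1` differs from compound 3 by 4-(ethoxycarbonyl)phenyl in place of but-3-yn-1-yl on an oxygen next to a carbonyl group. Among the compounds with values here, no measured step changes a group on this oxygen; the only nearby comparison, the swap at the carbonyl carbon between compound 2 and compound 3, stayed within the scatter. The step of a 1.0-fold higher number from compound 3 to compound 4 (0.02 log units; within the scatter) is therefore expected to be none beyond the scatter. Compound 4 is estimated at 30000 nM, between 10000 nM and 90000 nM.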

Compound 4, half-maximal effective concentration: 45600 nM
Beside the measured number, compound 4's estimate is 1.5-fold (0.18 log units) below it, within the range that was stated.
By their numbers in this assay, from the lowest: compounds 2, 3 and 4 (each within the scatter of the next, the first and the last beyond it). At a limit, above all of these: compound 1.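

In this assay, 4-(ethoxycarbonyl)phenyl in place of but-3-yn-1-yl on an oxygen next to a carbonyl group brings in an aromatic ring, and the step stays within the scatter (a 1.6-fold higher number from compound 3 to compound 4 (0.20 log units; within the scatter)). Against the amide compound 2, the 4-(ethoxycarbonyl)phenoxy group gives the first step beyond the scatter between two measured numbers (a 2.1-fold higher number from compound 2 to compound 4 (0.32 log units; beyond the scatter)). Compound 1 has only a limit, not a number: the limit of > 50000 nM in this assay, at which 1 of the 4 values shown sits. The step that rests on this limit gives only a floor, and that floor lies within the scatter (an at least 1.0-fold lower number from compound 1 to compound 4 (0.04 log units; that floor lies within the scatter)).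

Open, on these data alone, is what a carboxylic acid in place of that ethoxycarbonyl, or an unsubstituted phenyl, would give on this oxygen.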